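The compounds below may be only part of what the source reports. "The series", "measured", "known", "first", "only" and "open" are said of these compounds alone.

Within the data shown here, in a functional assay on A549 cells (Homo sapiens) for antiproliferative activity, read by MTT assay, with a stated time of 48 h (a lower number here means a stronger inhibitor, a higher number a weaker inhibitor), compound 1 `Cn1cc(-c2cnc3ccnc(N)c3c2)cn1` gives 33400 nM, the only true number so far. Compound 2 `CC(=O)Nc1ccc2ncc(-c3cnn(C)c3)cc2n1` gives > 50000 nM, which is a limit and not a number. Compound 3 `Cn1cc(-c2cnc3ccc(NC(=O)C4CC4)nc3c2)cn1` gives > 50000 nM, again a limit. Compound 1 therefore has no measured neighbour to be ranked against.

Next comes compound 4 `CC(=O)Nc1nccc2ncc(-c3cnn(C)c3)cc12`, which differs from compound 1 as follows: acetyl in place of hydrogen on a nitrogen on an aromatic ring. This is acetyl in place of hydrogen on a nitrogen on an aromatic ring, or amino to acetamido.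

Among the measured compounds shown here, no measured step covers this change. For the measured compounds named here, the one step available, a step that the two limits leave unreadable from compound 2 to compound 3, concerns a different replacement and has no readable size. The remaining guide is the limit of > 50000 nM in this assay, at which 2 of the 3 values shown sit. Compound 2, which also carries acetamido, gives > 50000 nM, a limit. That points towards weak activity in this assay for compound 4, though it fixes no size.

The expected step is small and within the scatter, tilted towards weaker inhibition: a 1.6-fold higher number from compound 1 to compound 4 (0.22 log units; within the scatter). A report of a limit instead of a number is considered more likely than not. For compound 4 the estimated value is 55000 nM, with an expected range of 25000 nM to 120000 nM.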

Compound 4, half-maximal inhibitory concentration: > 50000 nM
Compound 4 gave a limit, no number (the forecaster's own chance of this, stated with the estimate: 65%); the middle value lies beyond the limit too.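

The amino to acetamido change, with acetyl in place of hydrogen on a nitrogen on an aromatic ring, gives the first readable step from compound 1 in this assay: an at least 1.4-fold higher number from compound 1 to compound 4 (0.17 log units; that floor lies within the scatter). Only a floor is known, and that floor does not separate the two compounds beyond the usual scatter, so the change gives no sign of stronger inhibition at this position, though it does not prove a real loss either. Compound 4 carries a limit and not a number, and it adds to the cluster that now dominates the series: the limit of > 50000 nM in this assay, at which 3 of the 4 values shown sit.

From the compounds shown here alone, the true size of the step stays open, since the value of compound 4 could lie anywhere past its limit, and the steps between compounds that both carry limits cannot be read. Also open, going by these compounds, is whether a methyl group, a methanesulfonyl group or a longer acyl chain on this same nitrogen would give a true number in this assay, and on which side of compound 1 it would fall.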